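This account rests on a few compounds, and the source may have more. Where it says the series, first, only, none or still open, it means among the compounds named here.

Measured so far in a functional assay on A549 cells (Homo sapiens) for antiproliferative activity, read by sulforhodamine B assay, with a stated time of 48 h; on this read-out lower numbers stand for stronger inhibition and higher numbers for weaker inhibition:

compound 1 `COc1cc(C=C(C(=O)/C=C/c2cccc(OC)c2OC)C(=O)/C=C/c2cccc(OC)c2OC)cc(OC)c1O`: 240 nM
compound 2 `COc1ccc(C=C(C(=O)/C=C/c2cccc(OC)c2OC)C(=O)/C=C/c2cccc(OC)c2OC)cc1O`: 270 nM
compound 3 `COc1ccc(OC)c(/C=C/C(=O)C(=Cc2cc(OC)c(O)c(OC)c2)C(=O)/C=C/c2cc(OC)ccc2OC)c1`: 190 nM

Compound 4 `COc1ccc(OC)c(/C=C/C(=O)C(=Cc2ccc(OC)c(O)c2)C(=O)/C=C/c2cc(OC)ccc2OC)c1` has not yet been measured in this assay.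

Compounds 1 and 2 share a core. Compound 2 differs from compound 1 by 3-hydroxy-4-methoxyphenyl in place of 4-hydroxy-3,5-dimethoxyphenyl on a double-bonded chain carbon bound to a double-bonded chain carbon. In this assay, among the measured compounds shown here, this gave a 1.1-fold higher number from compound 1 to compound 2 (0.05 log units; within the scatter), so the one example of the change seen so far left the read-out essentially where it was.

Compound 3 is built from the same atoms as compound 1, joined differently; the difference between the two cores is not broken down here. In this assay compound 3 gives 190 nM, and compound 1 gives 240 nM, values that sit close together within the usual scatter, so the rearranged core neither helps nor hurts in any way that can be claimed from these two numbers.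

Compound 4 carries the same change on the core of compound 3: 3-hydroxy-4-methoxyphenyl in place of 4-hydroxy-3,5-dimethoxyphenyl on a double-bonded chain carbon bound to a double-bonded chain carbon. The place of the change is described in identical words for both pairs, so it is treated as the same change rather than merely one of the same kind. For the measured compounds named here, the expected step is a 1.1-fold higher number from compound 3 to compound 4 (0.04 log units; within the scatter), resting on the single earlier step of a 1.1-fold higher number from compound 1 to compound 2 (0.05 log units; within the scatter) and on compound 3 giving 190 nM. Going by the values given here, with only one prior example, the expectation is held loosely and the range is kept wide. Compound 4 is therefore expected to give about 210 nM in this assay, with an estimated range from 120 nM to 380 nM.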

Compound 4, half-maximal inhibitory concentration: 390 nM
Compound 4: the middle estimate sits 1.9-fold (0.27 log units) below what was measured; measured number above the stated range.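

In this assay, placing 3-hydroxy-4-methoxyphenyl in place of 4-hydroxy-3,5-dimethoxyphenyl on the core of compound 3 gives a 2.1-fold higher number from compound 3 to compound 4 (0.31 log units; beyond the scatter), a modest step that on its own lies beyond the usual scatter. Set beside the earlier example of the same change, this step cannot be told apart from it: the same change on two cores in this assay, a 1.1-fold higher number (0.05 log units; within the scatter) from compound 1 to compound 2 and a 2.1-fold higher number (0.31 log units; beyond the scatter) from compound 3 to compound 4, 1.8-fold (0.26 log units) apart, within the scatter of two such steps. Among the compounds shown here, the two pairs are therefore compatible with the change carrying over from one core to the other with a similar effect, but they show neither that the core of compound 3 responds more strongly than the core of compound 1 nor that the change raises the number on every core, since only one of the two steps lies beyond the scatter.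

On these data alone, all four compounds carry a hydroxyl and methoxy groups on the aryl ring at this place, so it remains open how the read-out would respond to an amine, a carboxylic acid or a fluorine there. Also open, as far as these compounds go, is whether the size of the step would hold on any core other than these two.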